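The compounds below may be only part of what the source reports. "The series", "measured", "known", "first", "only" and "open" are said of these compounds alone.

Compound 3 `CC(C)CCOc1cc(C(C)(C)C)ccc1CNC(=O)C(C)c1ccc(NS(C)(=O)=O)c(F)c1` gives the lowest number of the three measured in an assay on cells for antagonist activity at transient receptor potential cation channel subfamily V member 1 (Homo sapiens), read by FLIPR and calcium flux, with a stated time of 6 min (a lower number here means a stronger inhibitor, a higher number a weaker inhibitor), with compound 3 at 0.6 nM. Compound 2 `CC1CCN(c2cc(C(C)(C)C)ccc2CNC(=O)C(C)c2ccc(NS(C)(=O)=O)c(F)c2)CC1` sits close, at 0.7 nM, a gap a 1.2-fold lower number from compound 2 to compound 3 (0.07 log units; within the scatter); compound 1 `CC(C(=O)NCc1ccc(C(C)(C)C)cc1N1CCCCC1)c1ccc(NS(C)(=O)=O)c(F)c1` gives 1.9 nM, a gap a 3.2-fold lower number from compound 1 to compound 3 (0.50 log units; beyond the scatter), while a 2.7-fold lower number from compound 1 to compound 2 (0.43 log units; beyond the scatter). Compound 4 `CC(C(=O)NCc1ccc(C(C)(C)C)cc1OCc1ccc(F)cc1)c1ccc(NS(C)(=O)=O)c(F)c1` keeps the shared core and the ether oxygen but changes what hangs on it: 4-fluorophenyl in place of isobutyl on a saturated chain carbon bound to an oxygen on an aromatic ring. Within the data shown here, no measured step swaps a chain for an aromatic ring at this position; the steps involving compound 3 only show that the whole ether group works at least as well as the ring amines of compound 1 and compound 2, and the newer change cannot be read directly from them. Compound 4 is therefore expected to stay near compound 3, with a 1.7-fold higher number from compound 3 to compound 4 (0.22 log units; within the scatter), an estimate of 1 nM within 0.3 nM to 3.5 nM.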

Compound 4, inhibition constant: 3.8 nM
Estimate against measurement, compound 4: 3.8-fold (0.58 log units) below, outside the stated range (above it).
By their numbers in this assay, from the lowest: compounds 3 and 2 (each within the scatter of the next); then compounds 1 and 4 (each within the scatter of the next).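

The group on the ether oxygen matters: 4-fluorobenzyl in place of isopentyl gives a clear loss (a 6.3-fold higher number from compound 3 to compound 4 (0.80 log units; beyond the scatter)), so the oxygen alone does not keep the number low. The same group also falls behind the 4-methylpiperidin-1-yl of compound 2 (a 5.4-fold higher number from compound 2 to compound 4 (0.73 log units; beyond the scatter)), yet cannot be separated from the piperidin-1-yl of compound 1 (a 2.0-fold higher number from compound 1 to compound 4 (0.30 log units; within the scatter)). Nothing measured here bears on the reason for these steps. The compounds shown leave open whether plain benzyl, without the fluorine, would behave like 4-fluorobenzyl. They also leave open how a longer chain on the oxygen would compare with isopentyl.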